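This account rests on a few compounds, and the source may have more. Where it says the series, first, only, none or still open, it means among the compounds named here.

Measured compounds in a functional assay on a cell-free system (Platelet, plasma, Homo sapiens) for inhibition, with stated times of 1 min and 3 min; a lower number here means a stronger inhibitor, a higher number a weaker inhibitor:
compound 1 `CCCCCCNc1nc(SCC)nc2c1ncn2[C@@H]1O[C@H](CO)[C@@H](O)[C@H]1O` — "not determined" (no result reported)
compound 2 `CCCCCCNc1nc(SCCC)nc2c1ncn2[C@@H]1O[C@H](CO)[C@@H](O)[C@H]1O` — 102000 nM
compound 3 `CCCCCCNc1nc(SCCCC)nc2c1ncn2[C@@H]1O[C@H](CO)[C@@H](O)[C@H]1O` — "not determined" (no result reported)

Compound 1 stands without a number in this assay, and compound 3 likewise carries none, so the only figure in the set is that of compound 2, a weak one. Within the data shown here, no step between measured compounds is given, so nothing can be read on how the thioether chain affects the read-out.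

Compound 4 `CCSc1nc(NCc2ccccc2)c2ncn([C@@H]3O[C@H](CO)[C@@H](O)[C@H]3O)c2n1` differs from compound 1 by phenyl in place of pentyl on a saturated chain carbon bound to a nitrogen on an aromatic ring, hexylamino to benzylamino. Among the measured compounds shown here, with no comparable step in hand, no change beyond the scatter is expected in this assay in either direction. Since compound 2 gives 102000 nM, the series sits in a weak region. Compound 4 is therefore expected near 60000 nM, estimated within 8000 nM to 400000 nM.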

Compound 4, half-maximal inhibitory concentration: 176000 nM
Compound 4: the middle estimate sits 2.9-fold (0.47 log units) below what was measured; measured number inside the range.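

Compound 1, which differs from compound 4 in one place, carries no number in this assay so no step can be read. On these data alone, how hexylamino to benzylamino or thioether chain length moves inhibition stays open. No evidence bears on the result.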